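The compounds below may be only part of what the source reports. "The series", "measured", "known", "first", "only" and "open" are said of these compounds alone.

Compound 3 `Clc1cc(Cl)cc(CO[C@H]2CCCN(Cc3nccs3)[C@H]2c2ccccc2)c1` gives in an assay on isolated protein for activation of cGMP-dependent protein kinase 1 (Homo sapiens), read by ADP-Glo, with stated times of 120 min and 40 min (a higher number here means that more compound is needed for the effect, a lower number that less compound is needed), only the assay limit of > 200000 nM, which is a limit and not a number. Compound 1 `Cn1cc(CN2CCC[C@H](OCc3cc(Cl)cc(Cl)c3)[C@@H]2c2ccccc2)cn1` gives 110000 nM in this assay, and compound 2 `O=C(O)c1ccc(CN2CCC[C@H](OCc3cc(Cl)cc(Cl)c3)[C@@H]2c2ccccc2)s1` gives 76000 nM. Compound 4 `COc1ccc(C(=O)O)cc1CN1CCC[C@H](OCc2cc(Cl)cc(Cl)c2)[C@@H]1c1ccccc1` differs from compound 3 by 5-carboxy-2-methoxyphenyl in place of 1,3-thiazol-2-yl on a saturated chain carbon bound to an amine nitrogen in a ring. The measured steps that bear on this change are an at least 2.6-fold higher number from compound 2 to compound 3 (0.42 log units; beyond the scatter) and an at least 1.8-fold higher number from compound 1 to compound 3 (0.25 log units; that floor lies within the scatter); compound 4 carries a carboxylic acid again, as compound 2 does, now on a six-membered carbon ring. A return of the number toward the range of compound 2 is therefore expected, roughly an at least 2.8-fold lower number from compound 3 to compound 4 (0.45 log units; beyond the scatter). Compound 4 is estimated at 70000 nM, within a range from 25000 nM to 200000 nM, with some chance that only a limit is reported again.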

Compound 4, half-maximal effective concentration: 123000 nM
Compound 4: the middle estimate sits 1.8-fold (0.24 log units) below what was measured; the measured number falls inside the stated range.
By their numbers in this assay, from the lowest: compounds 2, 1 and 4 (each within the scatter of the next). At a limit, above all of these: compound 3.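

In this assay the change gives an at least 1.6-fold lower number from compound 3 to compound 4 (0.21 log units; that floor lies within the scatter), and compound 3 remains a limit, not a number: the limit of > 200000 nM in this assay, at which 1 of the 4 values shown sits.

The 5-carboxy-2-methoxyphenyl group does not separate from the other two groups at this position: a 1.6-fold higher number from compound 2 to compound 4 (0.21 log units; within the scatter) and a 1.1-fold higher number from compound 1 to compound 4 (0.05 log units; within the scatter). A six-membered aromatic ring of carbon only therefore gives a number here in the same range as the five-membered rings of compound 1 and compound 2.

On these data alone, what the methoxy group and the carboxylic acid each contribute in compound 4 stays open. So does the effect of an amine in place of the carboxylic acid on this ring.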